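A few compounds are considered here, and "the series" means these few. Any claim that something is new, unique, unknown or untested is made for them only; others in the source may bear on it.

Measured compounds:
compound 1 `COc1ccccc1-n1c(-c2coc3cc(C)c(Cl)cc3c2=O)nc(-c2ccccc2)c1-c1ccccc1` — "not determined" (no result reported) in an ADME assay on MCF-10A cells (Homo sapiens) for cytotoxicity, read by MTT assay, with a stated time of 72 h; on this read-out lower numbers stand for stronger inhibition and higher numbers for weaker inhibition
compound 2 `Cc1cc2occ(-c3nc(-c4ccccc4)c(-c4ccccc4)n3-c3ccc(Cl)cc3)c(=O)c2cc1Cl` — 92000 nM

Compound 1 `COc1ccccc1-n1c(-c2coc3cc(C)c(Cl)cc3c2=O)nc(-c2ccccc2)c1-c1ccccc1` carries a 2-methoxyphenyl on an aromatic nitrogen of its five-membered ring. In this assay compound 1 stands as "not determined" (no result reported), so it cannot be placed on the read-out at all. Compound 2 `Cc1cc2occ(-c3nc(-c4ccccc4)c(-c4ccccc4)n3-c3ccc(Cl)cc3)c(=O)c2cc1Cl` shares the core and in this assay compound 2 gives 92000 nM, a weak effect on these cells.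

Compound 3 `Cc1cc2occ(-c3nc(-c4ccccc4)c(-c4ccccc4)n3-c3ccc(Br)cc3)c(=O)c2cc1Cl` is the unmeasured member of the set. Compared with compound 1, the change is 4-bromophenyl in place of 2-methoxyphenyl on an aromatic nitrogen. Among the measured compounds shown here, no step between measured compounds is available here, and compound 1 itself has no value, so the size and direction of the move from compound 1 to compound 3 in this assay cannot be read from a measured pair; the only anchor is compound 2, whose structure is close to that of compound 3 and whose value is weak.

Resting on compound 2 and its 92000 nM, compound 3 is expected to give about 90000 nM in this assay, within 40000 nM to 200000 nM.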

Compound 3, half-maximal inhibitory concentration: > 100000 nM
Compound 3 ended at the assay's limit; the forecaster's own chance of this, stated with the estimate: 30%; middle value at least 1.1-fold (0.04 log units) away from the limit.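

Compound 3 gives > 100000 nM in this assay, which is a limit of the assay and not a number. Bromo in place of chloro on an aromatic carbon gives an at least 1.0-fold higher number from compound 2 to compound 3 (0.03 log units; that floor lies within the scatter), so on the phenyl ring carried by the aromatic nitrogen this exchange brings no stronger effect on these cells, and the weak result of compound 2 is no longer a single reading for the shared core. How large the step really is cannot be told, because only its floor can be read from a value at the limit: the limit of > 100000 nM in this assay, at which 1 of the 3 values shown sits.

From the compounds shown here alone, the step from compound 1 to compound 3 cannot be read, so how 2-methoxyphenyl compares with 4-bromophenyl on the aromatic nitrogen stays open. Also open is whether an amine or a carboxylic acid on that phenyl ring would bring the read-out down to clearly lower numbers in this assay, since the compounds shown differ there only by one halogen.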